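Swapping cyclohexyl for isobutyl on a weak inhibitor

This account rests on a few compounds, and the source may have more. Where it says the series, first, only, none or still open, it means among the compounds named here.

Compound 1 `COc1cc(/C=C/C(=O)/C=C(/C=C/c2ccc(OC(C)=O)c(OC)c2)NC2CCCCC2)ccc1OC(C)=O`: 9700 nM
Compound 2 `CCCNC(=C\C(=O)/C=C/c1ccc(O)c(OC)c1)/C=C/c1ccc(O)c(OC)c1`: > 25000 nM, a limit of the assay

For the measured compounds named here, in a functional assay on Caco-2 cells (Homo sapiens) for inhibition, read by MTT assay, with a stated time of 72 h (a higher number here means a weaker inhibitor, a lower number a stronger inhibitor), compound 1 gives 9700 nM, the only true number so far. For compound 2, the result > 25000 nM is a limit and not a number.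

Compound 3 `COc1cc(/C=C/C(=O)/C=C(/C=C/c2ccc(OC(C)=O)c(OC)c2)NCC(C)C)ccc1OC(C)=O` keeps the core of compound 1 and changes one group: isobutyl in place of cyclohexyl on an amine nitrogen. In words, isobutyl stands in place of cyclohexyl on an amine nitrogen. Going by the values given here, no measured pair of compounds differs in one place, so nothing yet shows how large such a step can be. The expectation in this assay therefore rests on compound 1 at 9700 nM, with no step beyond the scatter. The expected change is a 1.2-fold higher number from compound 1 to compound 3 (0.09 log units; within the scatter). For compound 3 the estimated value is 12000 nM, with an expected range of 5000 nM to 28000 nM.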

Compound 3, half-maximal inhibitory concentration: > 25000 nM
Compound 3 was reported as a limit; the forecaster's own chance of this, stated with the estimate: 20%; at least 2.0-fold (0.31 log units) between middle value and limit.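

The amine nitrogen now has its first readable step: in this assay, replacing cyclohexyl with isobutyl gives an at least 2.5-fold higher number from compound 1 to compound 3 (0.41 log units; beyond the scatter). With the rest of compound 1 kept, the group on this nitrogen therefore matters, and this change makes an already weak inhibitor weaker still. Compound 3 gives > 25000 nM, a limit and not a number, so the full size of the step cannot be read: the limit of > 25000 nM in this assay, at which 2 of the 3 values shown sit.

This single pair cannot separate the loss of the ring from the loss of carbon atoms. Cyclopentyl, phenyl or a longer chain such as n-hexyl on the same nitrogen would be needed to tell whether the ring itself counts, and whether any group here gives a stronger inhibitor than cyclohexyl.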